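Trimming one carbon from the imidazole side chain

The source may hold more compounds than are shown below. What is called first, only, known or untested is meant among the compounds shown, and "the series" means these compounds.

Compound 1 `O=C(O)c1ccccc1-c1ccc(CCc2ncc(CC3CCCCC3)[nH]2)cc1` is the reference point of this set. In an in vitro functional assay on cells for agonist activity at Bombesin receptor subtype-3 (Mus musculus), read by luminescence and calcium flux (a lower number here means that less compound is needed, a higher number that more compound is needed for the effect), compound 1 gives 7.3 nM, the lowest of the two numbers recorded. Within the data shown here, the only other measured compound, compound 2 `CCCCc1cnc(CCCc2ccc(-c3ccccc3C(=O)O)cc2)[nH]1`, carries a butyl group and a longer linker to the core; in this assay compound 2 gives 382 nM, a value that lies well beyond the scatter above that of compound 1, so the two cannot be treated as equivalent. Among the measured compounds shown here, no single-change step between measured compounds is available, so the gap tells little about any one change.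

Compound 3 `O=C(O)c1ccccc1-c1ccc(CCc2ncc(C3CCCCC3)[nH]2)cc1` differs from compound 1 in one place: cyclohexyl in place of cyclohexylmethyl on an aromatic carbon. No measured pair isolates this change, so its expected size rests on the general weight of the two compounds shown. The step from compound 1 to compound 3 is expected to be modest, if anything toward a higher number, that is a 2.7-fold higher number from compound 1 to compound 3 (0.44 log units; beyond the scatter). Compound 3 is therefore estimated at 20 nM, within a range of 5 nM to 80 nM.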

Compound 3, half-maximal effective concentration: 14.7 nM
For compound 3 the middle estimate is 1.4-fold (0.13 log units) above the measured one; low and high end bracket the measured number.
By their numbers in this assay, from the lowest: compounds 1 and 3 (each within the scatter of the next); then compound 2.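

With cyclohexyl in place of cyclohexylmethyl on the aromatic carbon, this assay shows a 2.0-fold higher number from compound 1 to compound 3 (0.30 log units; within the scatter), so compound 1 and compound 3 cannot be told apart in this measurement. Among these compounds, this is the first single-change step in the set, and it shows that at this position on the five-membered aromatic ring, the two carbon-only groups give numbers that stay within the usual scatter of each other. No measurement at hand explains this outcome.

What the compounds shown leave open is whether a phenyl group, an amine or a longer chain such as cyclohexylethyl on this carbon would stay within the same range. They also do not separate the shares of the butyl group and the longer linker in the higher number of compound 2.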